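The compounds below may be only part of what the source reports. "The series", "measured", "known", "first", "only" and "open" are said of these compounds alone.

In a functional assay on SF-539 cells (Homo sapiens) for inhibition, read by sulforhodamine B assay, with a stated time of 48 h (on this read-out higher numbers stand for weaker inhibition of growth and lower numbers for stronger inhibition of growth), two compounds sharing one core have been measured so far. Compound 1 (`Cc1ccc(C2=NN(c3ccc(S(C)(=O)=O)cc3)C(=O)CC2)cc1`) carries 4-methylphenyl and gives 1020 nM. Compound 2 (`Cc1cc(O)ccc1C1=NN(c2ccc(S(C)(=O)=O)cc2)C(=O)CC1`) carries 4-hydroxy-2-methylphenyl and gives 13200 nM, the higher of the two numbers and so the weaker inhibition of growth.

The next compound, compound 3 (`CCc1ccc(C2=NN(c3ccc(S(C)(=O)=O)cc3)C(=O)CC2)cc1`), departs from compound 2 at a single place, on a carbon with a double bond to nitrogen: 4-ethylphenyl in place of 4-hydroxy-2-methylphenyl on a carbon with a double bond to nitrogen. In words, 4-ethylphenyl stands in place of 4-hydroxy-2-methylphenyl.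

For the measured compounds named here, one measured step bears on this change, a 13-fold higher number from compound 1 to compound 2 (1.11 log units; beyond the scatter), which is large and beyond the scatter. Compound 3 gives up the hydroxy group of compound 2 and, like compound 1 at 1020 nM, has none, so the change should undo most of that step. The data say nothing about ethyl in place of methyl, which leaves the expected step somewhat smaller and towards a lower number in this assay. The expected step is an 8.8-fold lower number from compound 2 to compound 3 (0.94 log units; beyond the scatter). Compound 3 is estimated at 1500 nM, with an expected range of 500 nM to 4500 nM.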

Compound 3, concentration for 50% growth inhibition: 2350 nM
Beside the measured number, compound 3's estimate is 1.6-fold (0.19 log units) below it; low and high end bracket the measured number.
By their numbers in this assay, from the lowest: compound 1; then compound 3; then compound 2.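

In this assay, for the compounds shown here, the step to 4-ethylphenyl gives the first reading of chain length on this ring: methyl in place of hydrogen at the end of the chain brings a 2.3-fold higher number from compound 1 to compound 3 (0.36 log units; beyond the scatter), so even one added carbon there gives weaker inhibition of growth, and compound 1 stays the lowest of the three. The exchange of 4-hydroxy-2-methylphenyl for 4-ethylphenyl brings a 5.6-fold lower number from compound 2 to compound 3 (0.75 log units; beyond the scatter), which shows that a ring without the hydroxy group can regain much of the ground lost in compound 2, though this single step changes the hydroxy group, the ring methyl and the ethyl chain together. No measurement at hand offers an explanation for either step.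

The compounds shown leave open whether a longer chain such as propyl, or a branched one such as isopropyl, would push the number further up or whether the trend stops at ethyl. They also leave open how 4-hydroxyphenyl and 2-methylphenyl would stand, and these two groups would separate the share of the hydroxy group from that of the ring methyl in the weak result of compound 2.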